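This account rests on a few compounds, and the source may have more. Where it says the series, first, only, none or still open, it means among the compounds named here.

Measured compounds:
- Compound 1 `C/C(CN)=C(/F)CN(C[C@H]1Cc2ccccc2CN1)[C@H]1CCCc2cccnc21`: 97% in an ADME assay on microsomes from liver (Homo sapiens) for metabolic stability; a higher number here means that more of the compound is left, a lower number that less of the compound is left
- Compound 2 `C/C(CN(C[C@H]1Cc2ccccc2CN1)[C@H]1CCCc2cccnc21)=C(/F)CN`: 35% in this assay

Of the two numbers for this assay, compound 2 stands lowest, at 35%. Compound 3 `C/C(CN)=C(\F)CN(C[C@H]1Cc2ccccc2CN1)[C@H]1CCCc2cccnc21` has not yet been measured. It comes from compound 2 by one change 2-(aminomethyl)-1-fluoroprop-1-en-1-yl in place of 3-amino-2-fluoro-1-methylprop-1-en-1-yl on a saturated chain carbon bound to an amine nitrogen.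

Among the measured compounds shown here, only one measured step bears on this: a number 62 percentage points lower from compound 1 to compound 2 (beyond the scatter), which is large and beyond the scatter. It links the same two group names, read in the opposite direction. However, compound 1 and compound 3 differ in how the groups are arranged about the double bond, so that step may carry over only in part. A large rise is therefore expected, and the estimated step is a number 40 percentage points higher from compound 2 to compound 3 (beyond the scatter). For compound 3 the estimated value is 75%, with an expected range from 45% to 98%.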

Compound 3, percent of the compound remaining: 100%
The estimate for compound 3 lay 25 percentage points below the measured number; the measured number lies above the stated range.
By their numbers in this assay, from the lowest: compound 2; then compounds 1 and 3 (each within the scatter of the next).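

In this assay, the 2-(aminomethyl)-1-fluoroprop-1-en-1-yl group now appears in both double-bond configurations, and the exchange from the 3-amino-2-fluoro-1-methylprop-1-en-1-yl group gives a number 65 percentage points higher from compound 2 to compound 3 (beyond the scatter). The high number therefore goes with this group in either configuration, and the low number of compound 2 stands alone. The configuration itself leaves no readable mark at this position, with a number 3 percentage points higher from compound 1 to compound 3 (within the scatter), and the comparison is a clean one: the fact that compounds 1 and 3 differ only in the configuration as drawn

Still open, on these data alone, is how the 3-amino-2-fluoro-1-methylprop-1-en-1-yl group behaves with its double bond the other way round. The compounds shown also do not tell whether the number would hold with a chlorine in place of the fluorine, or with a hydroxyl in place of the amine.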